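Hydrazone Aryl Replacement on the Shared Core of Compound 1

A few compounds are considered here, and "the series" means these few. Any claim that something is new, unique, unknown or untested is made for them only; others in the source may bear on it.

Measured in a functional assay on HCT-116 cells (Homo sapiens) for antiproliferative activity, read by MTT assay; a lower number here means a stronger inhibitor, a higher number a weaker inhibitor:
compound 1 `Cn1c(=O)c(=O)n(C2CCCC2)c2nc(N/N=C/c3ccc(Cl)cc3)ncc21` — 9810 nM
compound 2 `Cn1c(=O)c(=O)n(C2CCCC2)c2nc(N/N=C/c3ccc(O)c(F)c3)ncc21` — 59300 nM
compound 3 `Cn1c(=O)c(=O)n(C2CCCC2)c2nc(N/N=C/c3cccs3)ncc21` — 52600 nM

Among the three measured compounds, compound 1 gives the lowest number in this assay. Its nearest neighbour is compound 3, with a 5.4-fold higher number from compound 1 to compound 3 (0.73 log units; beyond the scatter), and its furthest is compound 2, with a 6.0-fold higher number from compound 1 to compound 2 (0.78 log units; beyond the scatter). Between the two weaker compounds there is no separation to speak of, as a 1.1-fold lower number from compound 2 to compound 3 (0.05 log units; within the scatter).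

The unmeasured compound 4 `Cc1cc(C)c(/C=N/Nc2ncc3c(n2)n(C2CCCC2)c(=O)c(=O)n3C)c(C)c1` keeps the shared core and differs from compound 1 only at the hydrazone end: 2,4,6-trimethylphenyl in place of 4-chlorophenyl on a carbon with a double bond to nitrogen.

Among the compounds with values here, no measured step exchanges one carbocyclic aryl ring for another one without a heteroatom substituent, so the bearing is indirect. What is known is that both departures from the 4-chlorophenyl of compound 1 cost activity, by a 6.0-fold higher number from compound 1 to compound 2 (0.78 log units; beyond the scatter) and by a 5.4-fold higher number from compound 1 to compound 3 (0.73 log units; beyond the scatter). The trimethylphenyl ring is a third departure of similar scale, and a weaker number is therefore the more likely outcome, though the size is uncertain. The expected step is a 2.5-fold higher number from compound 1 to compound 4 (0.41 log units; beyond the scatter). Compound 4 is expected to give 25000 nM, with a range from 8000 nM to 80000 nM.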

Compound 4, half-maximal inhibitory concentration: 7920 nM
Estimate against measurement, compound 4: 3.2-fold (0.50 log units) above; measured number below the stated range.
By their numbers in this assay, from the lowest: compounds 4 and 1 (each within the scatter of the next); then compounds 3 and 2 (each within the scatter of the next).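

In this assay, the hydrazone position accepts the 2,4,6-trimethylphenyl ring of compound 4 on the same level as the 4-chlorophenyl ring, with a 1.2-fold lower number from compound 1 to compound 4 (0.09 log units; within the scatter) and thus no separation between the two, so the chlorine of compound 1 is not needed to reach that level and three methyl groups in its stead do not forfeit it. Both members of this pair stand apart from the other two compounds, shown by a 6.6-fold lower number from compound 3 to compound 4 (0.82 log units; beyond the scatter) and by a 7.5-fold lower number from compound 2 to compound 4 (0.87 log units; beyond the scatter), although compound 2 goes against any rule based on the ring alone: it too carries a six-membered aromatic ring of carbon only, yet it stays with the thiophen-2-yl compound 3 rather than with compounds 1 and 4. No measured property of these groups accompanies the numbers, so why the chlorinated and the trimethylated rings stand level remains unexplained.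

The compounds shown leave open how an unsubstituted phenyl ring or a ring with a single methyl group would compare with compounds 1 and 4. They also leave open whether an amine or a carboxylic acid on the ring would be tolerated at this position.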